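Thiophen-3-yl for furan-2-yl at the assay limit

A few compounds are considered here, and "the series" means these few. Any claim that something is new, unique, unknown or untested is made for them only; others in the source may bear on it.

For the measured compounds named here, in a functional assay on SNB-19 cells (Homo sapiens) for inhibition, read by MTT assay, with a stated time of 7 days (on this read-out higher numbers stand for weaker inhibition of growth and lower numbers for stronger inhibition of growth), compound 1 (`C[Si](C)(C)Cn1nnc2c(C(N)=O)ncn2c1=O`) gives 28400 nM and is the only compound so far with a true number. Compound 2 (`NC(=O)c1ncn2c(=O)n(Cc3ccco3)nnc12`) gives > 50000 nM as a limit of the assay and not a number. Its reading is the limit of > 50000 nM in this assay, at which 1 of the 2 values shown sits, and leaves its exact position open.

The change to compound 3 (`NC(=O)c1ncn2c(=O)n(Cc3ccsc3)nnc12`) is thiophen-3-yl in place of furan-2-yl on a saturated chain carbon bound to an aromatic nitrogen with thiophen-3-yl in place of furan-2-yl on a saturated chain carbon bound to an aromatic nitrogen, while the shared core stays the same. Going by the values given here, one measured step bears on this change, and it is an at least 1.7-fold higher number from compound 1 to compound 2 (0.24 log units; that floor lies within the scatter) at the same place in the molecule. Among the compounds with values here, that step replaces a group without a ring, and no measured step exchanges one five-membered aromatic ring for another. No step beyond the scatter is therefore expected in this assay in either direction. The step expected is a number no higher from compound 2 to compound 3 (the limit leaves the size open) as a rough estimate. For compound 3 the estimated value is 50000 nM with an expected range from 22000 nM to 110000 nM in this assay.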

Compound 3, concentration for 50% growth inhibition: > 50000 nM
Compound 3 gave a limit, no number (the forecaster's own chance of this, stated with the estimate: 55%); the middle value sits exactly at the limit.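

Compound 3 gives > 50000 nM in this assay, which is a limit of the assay and not a number. Putting thiophen-3-yl in place of the ring-free group on this saturated chain carbon gives an at least 1.7-fold higher number from compound 1 to compound 3 (0.24 log units; that floor lies within the scatter), the same floor that furan-2-yl showed earlier, so a second five-membered aromatic ring at this place also yields no true number. The exchange of furan-2-yl for thiophen-3-yl itself cannot be read, and the readings at this place now rest mostly on the assay limit: the limit of > 50000 nM in this assay, at which 2 of the 3 values shown sit.

As far as these compounds go, whether the two rings differ at all stays open, as does whether either really reads higher than the ring-free group, since both floors lie within the scatter. For the compounds shown here, also open is how an amine, a carboxylic acid or a longer chain on this saturated chain carbon would read in this assay, where compound 1, at 28400 nM, still holds the only true number.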